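A Chloro-for-Methyl Swap in a Set Without Measured Activity

This account rests on a few compounds, and the source may have more. Where it says the series, first, only, none or still open, it means among the compounds named here.

Compound 1 `CN1C(=O)C2(C(C#N)=C(N)Oc3cc4oc(-c5ccccc5)cc(=O)c4c(O)c32)c2cccc(Cl)c21` reaches only the limit > 50000 nM in a functional assay on NCI-H1299 cells (Homo sapiens) for antiproliferative activity, read by MTT assay, with a stated time of 48 h; on this read-out higher numbers stand for weaker inhibition and lower numbers for stronger inhibition. Compound 2 `Cc1cccc2c1N(Cc1ccccc1)C(=O)C21C(C#N)=C(N)Oc2cc3oc(-c4ccccc4)cc(=O)c3c(O)c21` likewise gives only the limit > 50000 nM in this assay. Compound 3 `N#CC1=C(N)Oc2cc3oc(-c4ccccc4)cc(=O)c3c(O)c2C12C(=O)N(Cc1ccccc1)c1ccc(Br)cc12` also stops at the limit > 50000 nM in this assay.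

On these numbers compound 2 stands nowhere apart: all three values sit at the same limit (the limit of > 50000 nM in this assay, at which 3 of the 3 values shown sit), so no order among them can be read. Compound 4 `N#CC1=C(N)Oc2cc3oc(-c4ccccc4)cc(=O)c3c(O)c2C12C(=O)N(Cc1ccccc1)c1c(Cl)cccc12` differs from compound 2 by chloro in place of methyl on an aromatic carbon. No step between measured compounds has been seen, and the shared core has shown no measurable inhibition in any of the three, so no movement beyond the scatter is expected in this assay. Compound 4 is expected to give about 60000 nM, with a range from 20000 nM to 200000 nM. The step that the limit leaves unreadable from compound 2 to compound 4 is estimated to stay within the scatter.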

Compound 4, half-maximal inhibitory concentration: > 50000 nM
Compound 4 gave a limit, no number; the forecaster's own chance of this, stated with the estimate: 85%; the middle value is on the limit's open side.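

Compound 4 gives > 50000 nM as a limit in this assay as well, so no step from compound 1 or compound 2 to compound 4 can be read: the limit of > 50000 nM in this assay, at which 4 of the 4 values shown sit.

Going by these compounds, whether any change on the shared core gives a measurable value in this assay stays open.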